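The source may report more compounds than this note shows. Statements on the series, on what has been measured and on what is new or still open speak of the compounds shown alone.

Compound 1 `O=C(CCCCC(S)CCS)Nc1ccccc1` and compound 2 `O=C(CCCCC(S)CCS)Nc1ccc(Cl)cc1` share one core; compound 2 differs from compound 1 by chloro in place of hydrogen on an aromatic carbon. In a functional assay on HO8910 cells (Homo sapiens) for inhibition, read by MTT assay, with a stated time of 24 h, tested at 1 ug/mL (on this read-out lower numbers stand for less inhibition of growth and higher numbers for more inhibition of growth at the one concentration tested), compound 1 gives 6.38%, and compound 2 gives 2.81%, so that a number 3.6 percentage points lower from compound 1 to compound 2 (within the scatter). Compound 3 `CC(=O)SCCC(CCCCC(=O)Nc1ccccc1)SC(C)=O` rests on another core, and the difference between the two cores is not broken down here; in this assay compound 3 gives 10.6%. Compound 4 `CC(=O)SCCC(CCCCC(=O)Nc1ccccc1Cl)SC(C)=O` differs from compound 3 by chloro in place of hydrogen on an aromatic carbon. This is the same kind of change as from compound 1 to compound 2, but the place is not the same: in compound 2 the chloro is para to a large group, in compound 4 it is ortho to a large group. Because a number 3.6 percentage points lower from compound 1 to compound 2 (within the scatter) stayed within the scatter, the expected step is a number 2.6 percentage points lower from compound 3 to compound 4 (within the scatter). Compound 4 is therefore estimated at 8%, between 0% and 20%.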

Compound 4, percent growth inhibition at one concentration: "not active" (no number reported)
The entry for compound 4 holds no number; no gap can be computed for the estimate.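

Within the data shown here, compound 4 is reported in this assay only as not active, without a number, so no step from compound 3 to compound 4 can be read. Nothing available here accounts for this result. The compounds shown leave open how far phenyl to 2-chlorophenyl shifts growth inhibition on this core.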